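Sorbate ester of the hydroxyethyl series: tolerability outlook

A few compounds are considered here, and "the series" means these few. Any claim that something is new, unique, unknown or untested is made for them only; others in the source may bear on it.

Two members of the series have a number in an ADME assay on HepG2 2.2.15 cells (Homo sapiens) for cytotoxicity; a higher number here means that more compound is tolerated, a lower number that less compound is tolerated. Compound 1 `O=c1c(CCO)c(-c2ccccc2Cl)c2cc(Cl)ccc2n1-c1ccccc1` gives 26000 nM. Compound 2 `O=C(OCCc1c(-c2ccccc2Cl)c2cc(Cl)ccc2[nH]c1=O)c1ccc([N+](=O)[O-])cc1` gives 1600000 nM, the higher of the two numbers; compound 1 lies well below it, beyond the scatter. Within the data shown here, these two compounds differ in more than one place, so no single step between them is computed, and their two values are all that can be said of the pair.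

Compound 3 `C/C=C/C=C/C(=O)OCCc1c(-c2ccccc2Cl)c2cc(Cl)ccc2[nH]c1=O` is the next ester to be measured in this assay . Its difference from compound 2:

penta-1,3-dien-1-yl in place of 4-nitrophenyl on a carbonyl carbon

The ester itself and the core of compound 2 are kept; only the acyl part is exchanged, an aromatic ring bearing the nitro group giving way to a short open chain with two double bonds.

Among the measured compounds shown here, no measured step of this kind exists, so the expectation rests on compound 2 alone, which is tolerated at 1600000 nM. The step from compound 2 to compound 3 is expected to be downward but small, a 2.7-fold lower number from compound 2 to compound 3 (0.43 log units; beyond the scatter), and may well fall within the scatter. For compound 3 the estimated value in this assay is 600000 nM, with a range from 100000 nM to 2500000 nM.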

Compound 3, half-maximal cytotoxic concentration: 440000 nM
Compound 3: middle estimate off by 1.4-fold (0.13 log units), on the high side; the measured number falls inside the stated range.
By their numbers in this assay, from the lowest: compound 1; then compound 3; then compound 2.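

In this assay, the acyl part on the carbonyl carbon now has one measured step: a 3.6-fold lower number from compound 2 to compound 3 (0.56 log units; beyond the scatter). The exchange of 4-nitrophenyl for penta-1,3-dien-1-yl thus moves the number beyond the scatter, though only modestly, and shows that this position tolerates the loss of the aromatic ring and the nitro group together with a change of this size. Nothing at hand explains the direction or size of this step.

With a single step at this position, the share of the aromatic ring and that of the nitro group cannot be told apart, as both leave in the same exchange; a plain phenyl group on the same carbonyl carbon would address the first, and a saturated pentyl chain would show whether the two double bonds of the penta-1,3-dien-1-yl group matter. Also open, going by these compounds, is how far the ester link itself shapes the number, a question that a free hydroxyl group on the otherwise unchanged core of compound 2 or an amide in place of the ester would address.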